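From a Dichlorophenyl Limit toward a Thiophene Estimate

A few compounds are considered here, and "the series" means these few. Any claim that something is new, unique, unknown or untested is made for them only; others in the source may bear on it.

Three compounds share one core and differ only in the aryl group attached to it. Compound 1 `Cn1cc(/C=C2/C(=O)Nc3ccccc32)c2cc(Nc3nccc(-c4ccc(O)cc4)n3)ccc21` carries a 4-hydroxyphenyl group; in a functional assay on LNCaP cells (Homo sapiens) for cytotoxicity, read by MTT assay, with a stated time of 48 h (a higher number here means a weaker inhibitor, a lower number a stronger inhibitor), compound 1 gives 10800 nM. Compound 2 `Cn1cc(/C=C2/C(=O)Nc3ccccc32)c2cc(Nc3nccc(-c4ccc(F)cc4)n3)ccc21` carries a 4-fluorophenyl group, and in this assay compound 2 gives 16300 nM; the change a 1.5-fold higher number from compound 1 to compound 2 (0.18 log units; within the scatter) is therefore hardly a change at all. Compound 3 `Cn1cc(/C=C2/C(=O)Nc3ccccc32)c2cc(Nc3nccc(-c4ccc(Cl)cc4Cl)n3)ccc21` carries a 2,4-dichlorophenyl group. For compound 3 this assay reports only a limit, > 100000 nM, which is the limit of > 100000 nM in this assay, at which 1 of the 3 values shown sits. So compound 3 stands at the weak end of this small set: the steps of an at least 9.2-fold higher number from compound 1 to compound 3 (0.96 log units; beyond the scatter) and an at least 6.1-fold higher number from compound 2 to compound 3 (0.78 log units; beyond the scatter) both run beyond the scatter.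

Compound 4 `Cn1cc(/C=C2/C(=O)Nc3ccccc32)c2cc(Nc3nccc(-c4cccs4)n3)ccc21` is not yet measured. It differs from compound 3 by thiophen-2-yl in place of 2,4-dichlorophenyl on an aromatic carbon. The two measured steps that bear on this change both show that moving from a single para-substituted phenyl to the 2,4-dichlorophenyl group costs activity, so moving away from that group toward a smaller five-membered ring is expected to win some of it back. The expected step of an at least 5.0-fold lower number from compound 3 to compound 4 (0.69 log units; beyond the scatter) in this assay points toward a lower number. For compound 4 the estimate in this assay is 20000 nM, expected to fall between 6000 nM and 80000 nM.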

Compound 4, half-maximal inhibitory concentration: 10400 nM
Compound 4: middle estimate off by 1.9-fold (0.28 log units), on the high side; measured number inside the range.
By their numbers in this assay, from the lowest: compounds 4, 1 and 2 (each within the scatter of the next). At a limit, above all of these: compound 3.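

Until compound 4, only phenyl groups had been seen at this position, and compound 4 shows that a five-membered aromatic ring with one sulfur atom is tolerated there in this assay: the steps of a 1.6-fold lower number from compound 2 to compound 4 (0.20 log units; within the scatter) and a 1.0-fold lower number from compound 1 to compound 4 (0.02 log units; within the scatter) both stay within the scatter. The 2,4-dichlorophenyl group is thus the only group shown that stands apart, and replacing it with thiophen-2-yl gives the step of an at least 9.6-fold lower number from compound 3 to compound 4 (0.98 log units; beyond the scatter), which brings the number back level with those of the two single-substituent phenyl compounds. Compound 3 has only a limit, so that step gives a minimum size and not a measured one: the limit of > 100000 nM in this assay, at which 1 of the 4 values shown sits.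

The compounds shown leave open which of the two chlorines goes with the loss of activity, something a phenyl group carrying a single chlorine could help to separate. They also leave open whether any group at this position, such as an amine or a carboxylic acid on the ring, can bring the number lower by more than the scatter.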